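Ethyl at the Pyrazole Carbon: Extrapolating from Methyl

The compounds below may be only part of what the source reports. "The series", "measured", "known", "first", "only" and "open" are said of these compounds alone.

Measured compounds:
compound 1, `Cc1n[nH]cc1-c1cc2c(s1)C(=O)NC(C)(C)N2C`, 54 nM
compound 2, `CN1c2cc(-c3cn[nH]c3)sc2C(=O)NC1(C)C`, 130 nM
compound 3, `Cc1c(-c2cn[nH]c2)sc2c1N(C)C(C)(C)NC2=O`, 44 nM

In an assay for inhibition of Rho-associated protein kinase 1 (Homo sapiens), read by TR-FRET, with stated times of 5 min and 2 h (a higher number here means a weaker inhibitor, a lower number a stronger inhibitor), compound 2 gives the highest of the three numbers; its nearest neighbour is compound 1, at 54 nM, and the furthest is compound 3, at 44 nM. Compound 4, `CCc1n[nH]cc1-c1cc2c(s1)C(=O)NC(C)(C)N2C`, has not yet been measured. It differs from compound 2 in one place: ethyl in place of hydrogen on an aromatic carbon.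

Going by the values given here, two measured steps bear on this change. Within the shared core, hydrogen in place of methyl on an aromatic carbon gave a 2.4-fold higher number from compound 1 to compound 2 (0.38 log units; beyond the scatter), and methyl in place of hydrogen on an aromatic carbon gave a 3.0-fold lower number from compound 2 to compound 3 (0.47 log units; beyond the scatter). Both are modest and both lie beyond the scatter, pointing the same way: a small alkyl group on an aromatic carbon of this core is accompanied by a lower number in this assay. Ethyl is one carbon longer than methyl, and no measured compound carries ethyl, so whether the additional carbon adds to or subtracts from the effect is unknown.

Compound 4 is therefore expected to give a lower number than compound 2, by a step of about a 2.9-fold lower number from compound 2 to compound 4 (0.46 log units; beyond the scatter), on the scale of the methyl steps. The estimate for compound 4 in this assay is 45 nM, with a range from 15 nM to 130 nM.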

Compound 4, half-maximal inhibitory concentration: 350 nM
Compound 4: middle estimate off by 7.8-fold (0.89 log units), on the low side, outside the stated range (above it).
By their numbers in this assay, from the lowest: compounds 3 and 1 (each within the scatter of the next); then compound 2; then compound 4.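

At this carbon of the five-membered aromatic ring with 2 nitrogen, the direction of the step in this assay depends on which alkyl group is present: removing methyl gives a 2.4-fold higher number from compound 1 to compound 2 (0.38 log units; beyond the scatter), whereas ethyl in place of hydrogen gives a 2.7-fold higher number from compound 2 to compound 4 (0.43 log units; beyond the scatter), so the two groups fall on opposite sides of hydrogen. The one carbon that separates methyl from ethyl here comes with a 6.5-fold higher number from compound 1 to compound 4 (0.81 log units; beyond the scatter), so the outcome at this carbon turns on that single added carbon. The methyl of compound 3 sits on a different aromatic carbon of the shared core, and the lower number it gives does not carry over to ethyl at this position, so methyl and ethyl cannot be read as one class of small alkyl group here.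

The data in hand give no explanation for this reversal. Still open, on these data alone, is whether a longer chain such as propyl, a branched group such as isopropyl, or a cyclopropyl ring at this carbon continues the rise, and whether ethyl on the aromatic carbon that carries methyl in compound 3 behaves as it does here.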